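Working notes: methyl-to-fluoro exchange and cytotoxicity

The source may hold more compounds than are shown below. What is called first, only, known or untested is meant among the compounds shown, and "the series" means these compounds.

Measured in an ADME assay on MT4 cells (Homo sapiens) for cytotoxicity, read by spectrophotometry, with a stated time of 5 days; on this read-out lower numbers stand for higher toxicity in this test and higher numbers for lower toxicity in this test:
compound 1, `CONC(=S)N/N=C1\C(=O)N(CN(C)C)c2ccc(F)cc21`, gives 560000 nM
compound 2, `CCn1cc(C(=O)O)c(=O)c2cc(F)c(N3CCN(CN4C(=O)/C(=N\NC(=S)NO)c5cc(C)ccc54)CC3)cc21`, gives 327000 nM
compound 3, `CONC(=S)N/N=C1\C(=O)N(CN(C)C)c2ccc(C)cc21`, gives 622000 nM

Compound 1 and compound 3 share one core and differ in a single place: fluoro in place of methyl on an aromatic carbon. The step that goes with it, a 1.1-fold lower number from compound 3 to compound 1 (0.05 log units; within the scatter), is small enough to count as no change in this assay. Compound 2 carries a different core; the difference between its core and that of compound 3 is not broken down here. The value of compound 2 and the values of compound 1 and compound 3 all fall within the usual scatter of one another, so none of the three is separated from the others in this assay.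

Compound 4, `CCn1cc(C(=O)O)c(=O)c2cc(F)c(N3CCN(CN4C(=O)/C(=N\NC(=S)NO)c5cc(F)ccc54)CC3)cc21`, has not been measured. It stands to compound 2 as compound 1 stands to compound 3: fluoro in place of methyl on an aromatic carbon. The place description is the same word for word in both pairs, so this is the same change on a different core.

Going by the values given here, the expectation for compound 4 rests on the only measured instance of this change, compound 3 to compound 1, where a 1.1-fold lower number from compound 3 to compound 1 (0.05 log units; within the scatter) stayed within the scatter. The step from compound 2 to compound 4 is therefore expected to be about as small, a 1.1-fold lower number from compound 2 to compound 4 (0.04 log units; within the scatter). Compound 4 is estimated at 300000 nM in this assay, with a likely range from 150000 nM to 600000 nM.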

Compound 4, half-maximal cytotoxic concentration: 208000 nM
Beside the measured number, compound 4's estimate is 1.4-fold (0.16 log units) above it; the measured number falls inside the stated range.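

In this assay, fluoro in place of methyl on an aromatic carbon gives a 1.6-fold lower number from compound 2 to compound 4 (0.20 log units; within the scatter), so on this second core the exchange again stays inside the usual scatter. Set beside the first instance of the exchange, the new step cannot be told apart from it: the same change on two cores in this assay, a 1.1-fold lower number (0.05 log units; within the scatter) from compound 3 to compound 1 and a 1.6-fold lower number (0.20 log units; within the scatter) from compound 2 to compound 4, 1.4-fold (0.15 log units) apart, within the scatter of two such steps. Across these two cores, the exchange can therefore be carried over without a step that stands out from the scatter, but with only two pairs this does not show that the exchange has any effect of its own on the read-out, nor that either core responds differently from the other, and it gives no rule for the series as a whole.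

Both pairs cover only methyl and fluoro on this aromatic carbon, which leaves open how a chloro, methoxy or trifluoromethyl group in the same place would read in this assay. Also open, from the compounds shown here alone, is whether the exchange stays this small on a core that lacks both the dimethylamino group of compound 1 and the carboxylic acid of compound 2.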